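The source may report more compounds than this note shows. Statements on the series, on what has been measured and on what is new or still open speak of the compounds shown alone.

Measured compounds:
compound 1, `CCOC(=O)C1CCN(C(=O)CN2CN(c3ccccc3)C3(CCN(C(=O)c4ccc(C5CCCCC5)cc4)CC3)C2=O)CC1`; in an assay on HEK293 cells for displacement of a labelled ligand from NPC1-like intracellular cholesterol transporter 1 (Homo sapiens) (on this read-out higher numbers stand for weaker inhibition and lower numbers for stronger inhibition), compound 1 gives 900 nM.
compound 2, `CC(C)(C)OC(=O)NCCCCCNC(=O)CN1CN(c2ccccc2)C2(CCN(C(=O)c3ccc(C(C)(C)C)cc3)CC2)C1=O`; in this assay compound 2 gives 13700 nM.
compound 3, `COC(=O)CCCNC(=O)CN1CN(c2ccccc2)C2(CCN(C(=O)c3ccc(C4CCCCC4)cc3)CC2)C1=O`; in this assay compound 3 gives 2500 nM.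

Compound 2 holds the highest number of the three; compound 3 stands nearest to it and compound 1 furthest, both gaps beyond the scatter. Compound 4, `CC(C)(C)c1ccc(C(=O)N2CCC3(CC2)C(=O)N(CC(=O)NCCC(=O)O)CN3c2ccccc2)cc1`, is not yet measured. It differs from compound 2 thus: carboxy in place of 3-((tert-butoxycarbonyl)amino)propyl on a saturated chain carbon, two bonds along the chain from an amide-type nitrogen. Among the measured compounds shown here, no measured step varies this part of the chain alone. For the measured compounds named here, the only measured step, a 2.8-fold higher number from compound 1 to compound 3 (0.44 log units; beyond the scatter), exchanges a group on a carbonyl carbon and is modest; compound 2 additionally differs from compounds 1 and 3 in another group, so their numbers give no direct guide. A step of modest size in either direction is plausible, and none beyond the scatter is expected. Compound 4 is therefore estimated at 10000 nM, range 3000 nM to 30000 nM, which means an expected step of a 1.4-fold lower number from compound 2 to compound 4 (0.14 log units; within the scatter).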

Compound 4, half-maximal inhibitory concentration: 11400 nM
Estimate against measurement, compound 4: 1.1-fold (0.06 log units) below; measured number inside the range.
By their numbers in this assay, from the lowest: compound 1; then compound 3; then compounds 4 and 2 (each within the scatter of the next).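

In this assay, carboxy in place of 3-((tert-butoxycarbonyl)amino)propyl on a saturated chain carbon, two bonds along the chain from an amide-type nitrogen, gives a 1.2-fold lower number from compound 2 to compound 4 (0.08 log units; within the scatter), the first step read at this position. A group of 11 heavy atoms and one of 3 heavy atoms thus cannot be told apart here, with both compounds in the weak end of the series. Nothing measured alongside these numbers explains this result. Open, going by these compounds, is whether a free amine at this position, or a longer chain ending in a carboxylic acid, would read the same. Also open, on these data alone, is whether the exchange holds with the cyclohexyl group of compound 1 and compound 3 in place of tert-butyl.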